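Turning the Amide Around: An Expectation for Compound 4

A few compounds are considered here, and "the series" means these few. Any claim that something is new, unique, unknown or untested is made for them only; others in the source may bear on it.

Of the compounds shown here, three sharing one core have been measured in a functional assay on KBVIN cells (Homo sapiens) for antiproliferative activity, read by sulforhodamine B assay, with a stated time of 3 days; on this read-out lower numbers stand for stronger inhibition of growth and higher numbers for weaker inhibition of growth. Compound 1 `O=C(c1cccc(Nc2ncc(F)c(Nc3ccc(F)cc3)n2)c1)N1CCCCC1` gives 13800 nM, compound 2 `CN(C)CC(=O)Nc1cccc(Nc2ncc(F)c(Nc3ccc(F)cc3)n2)c1` gives 1810 nM, and compound 3 `O=C(Nc1cc(Cl)cc(Cl)c1)c1cccc(Nc2ncc(F)c(Nc3ccc(F)cc3)n2)c1` gives 20700 nM, the highest of the three numbers. Its nearest neighbour is seen in a 1.5-fold higher number from compound 1 to compound 3 (0.18 log units; within the scatter) and its furthest in an 11-fold higher number from compound 2 to compound 3 (1.06 log units; beyond the scatter). Compound 4 `O=C(Nc1cccc(Nc2ncc(F)c(Nc3ccc(F)cc3)n2)c1)c1ccncc1` has not been measured; it differs from compound 3 by ((pyridin-4-yl)carbonyl)amino in place of (3,5-dichlorophenyl)carbamoyl on an aromatic carbon. The first of those two steps swapped only the group on the carbonyl carbon, the second exchanged an acylamino group for a carbamoyl group and was large. Since compound 4 again carries a ((pyridin-4-yl)carbonyl)amino group, compound 4 is expected to show a 4.1-fold lower number from compound 3 to compound 4 (0.62 log units; beyond the scatter). Compound 4 is estimated at 5000 nM, with a range from 1500 nM to 16000 nM.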

Compound 4, concentration for 50% growth inhibition: 4570 nM
Beside the measured number, compound 4's estimate is 1.1-fold (0.04 log units) above it; low and high end bracket the measured number.
By their numbers in this assay, from the lowest: compound 2; then compound 4; then compounds 1 and 3 (each within the scatter of the next).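

Both compounds with an acylamino group at this aromatic carbon now give lower numbers than both with a carbonyl attached directly to the ring: replacing (3,5-dichlorophenyl)carbamoyl with ((pyridin-4-yl)carbonyl)amino gives a 4.5-fold lower number from compound 3 to compound 4 (0.66 log units; beyond the scatter) in this assay, and replacing (piperidin-1-yl)carbonyl gives a 3.0-fold lower number from compound 1 to compound 4 (0.48 log units; beyond the scatter). The advantage therefore does not require the (dimethylamino)methyl group, although the group on the carbonyl still matters, with a 2.5-fold higher number from compound 2 to compound 4 (0.40 log units; beyond the scatter). No measurement here explains these differences. Still open, going by these compounds, is whether a plain phenyl on the carbonyl would match pyridin-4-yl, and whether a longer chain ending in a dimethylamino group would go below compound 2.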